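The source may hold more compounds than are shown below. What is called first, only, known or untested is meant among the compounds shown, and "the series" means these compounds.

Measured in an ADME assay on TZM-b1 cells (Homo sapiens) for cytotoxicity, read by XTT assay, with a stated time of 3 days; on this read-out lower numbers stand for higher toxicity in this test and higher numbers for lower toxicity in this test:
Compound 1 `Cc1nc(C(NC(=O)C(=O)Nc2ccc(Cl)cc2)C2CCCCN2C)sc1CCO` gives 36000 nM.
Compound 2 `Cc1ccc(NC(=O)C(=O)NC(c2nc(C)c(CO)s2)C2CCCCN2)cc1F` gives > 88000 nM, a limit of the assay rather than a number.
Compound 3 `Cc1nc(C(NC(=O)C(=O)Nc2ccc(F)cc2)C2CCCCN2)sc1CCO` gives > 88000 nM, likewise a limit of the assay.

Among the compounds with values here, compound 1 thus holds the only measured number in this assay; the other two values sit at the limit of > 88000 nM in this assay, at which 2 of the 3 values shown sit. Within the data shown here, no pair of measured compounds differs in a single place, so no step within the measured set can be counted. Compound 4 `Cc1nc(C(NC(=O)C(=O)Nc2ccc(Cl)cc2)C2CCCNC2)sc1CCO` is next to be read in this assay. Compared with compound 1 it carries piperidin-3-yl in place of 1-methylpiperidin-2-yl on a saturated chain carbon bound to an amide-type nitrogen and an aromatic carbon, that is, piperidin-3-yl in place of 1-methylpiperidin-2-yl on a saturated chain carbon bound to an amide-type nitrogen and an aromatic carbon. All three measured compounds show weak toxicity in this test, and compound 4 is expected to stay in that region. The expected step is a 1.4-fold higher number from compound 1 to compound 4 (0.14 log units; within the scatter), none beyond the scatter. Compound 4 is estimated at 50000 nM, within 20000 nM to 120000 nM.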

Compound 4, half-maximal cytotoxic concentration: 59400 nM
For compound 4 the middle estimate is 1.2-fold (0.07 log units) below the measured one, within the range that was stated.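

In this assay, within the data shown here, piperidin-3-yl in place of 1-methylpiperidin-2-yl on a saturated chain carbon bound to an amide-type nitrogen and an aromatic carbon gives a 1.7-fold higher number from compound 1 to compound 4 (0.22 log units; within the scatter) as the first readable step. This position therefore accepts the exchange, with its added hydrogen-bond donor, without a shift beyond the scatter. The read-out still meets its limit elsewhere in the series: the limit of > 88000 nM in this assay, at which 2 of the 4 values shown sit.

The step alters the ring's methyl and its point of attachment together, so the two cannot be separated. On these data alone, an open-chain amine such as dimethylaminomethyl or a carboxylic acid at this position remains open.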